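The compounds below may be only part of what the source reports. "The series", "measured", "known", "first", "only" and "open" are said of these compounds alone.

Here are the compounds measured so far in a functional assay on HeLa cells (Homo sapiens) for cytotoxicity, read by WST assay, with a stated time of 48 h (a lower number here means a stronger inhibitor, a higher number a weaker inhibitor), and their values.

Compound 1 `COc1ccc(CCC[C@H]2C[C@@H]([C@@H](O)c3ccc(OC)c(OC)c3)CO[C@@H]2c2ccc(OC)c(OC)c2)cc1OC` gives 37700 nM
Compound 2 `COc1ccc(/C=C/C[C@H]2C[C@@H]([C@@H](O)c3ccc(OC)c(OC)c3)CO[C@@H]2c2ccc(OC)c(OC)c2)cc1` gives 12200 nM
Compound 3 `O[C@@H](c1ccccc1)[C@H]1CO[C@H](c2ccccc2)[C@@H](C/C=C/c2ccccn2)C1` gives 33800 nM

Compound 3 at 33800 nM lies within the scatter of compound 1, while compound 2 has the clearly lower number.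

Compound 4 `Cc1ccc(/C=C/C[C@H]2C[C@@H]([C@@H](O)c3ccccc3)CO[C@@H]2c2ccccc2)cc1C` carries 3,4-dimethylphenyl in place of pyridin-2-yl on a double-bonded chain carbon bound to a double-bonded chain carbon and otherwise matches compound 3.

Among the compounds with values here, only one measured step bears on this change, and only loosely. It is a 3.1-fold lower number from compound 1 to compound 2 (0.49 log units; beyond the scatter) and it is modest. Within the data shown here, it alters the same side chain, giving 2-(4-methoxyphenyl)ethenyl in place of 2-(3,4-dimethoxyphenyl)ethyl, but no measured step replaces pyridin-2-yl. Among the measured compounds shown here, compound 2 at 12200 nM is the one measured compound with a carbon-only ring on an ethenyl chain, though the rest of it differs from compound 4.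

The expected step in this assay is therefore small, an estimated 1.7-fold lower number from compound 3 to compound 4 (0.23 log units; within the scatter) and not clearly beyond the scatter. Compound 4 is estimated at 20000 nM with an expected range of 8000 nM to 45000 nM in this measurement.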

Compound 4, half-maximal inhibitory concentration: 10000 nM
Compound 4: the middle estimate sits 2.0-fold (0.30 log units) above what was measured, and the stated range covers the measured number.
By their numbers in this assay, from the lowest: compounds 4 and 2 (each within the scatter of the next); then compounds 3 and 1 (each within the scatter of the next).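

In this assay, within the data shown here, the step at this place is a 3.4-fold lower number from compound 3 to compound 4 (0.53 log units; beyond the scatter), the first measured change of pyridin-2-yl on a double-bonded chain carbon bound to a double-bonded chain carbon, and it shows that the ring at the end of the ethenyl chain affects the number while the rest of the molecule stays the same. The swap removes the ring nitrogen of pyridin-2-yl and brings in the methyl groups of 3,4-dimethylphenyl in a single move, so this one step cannot show which of the two matters. No measurement shown here gives a reason for the lower number.

As far as these compounds go, it remains open how a plain phenyl ring would compare at this place, which would separate the loss of the nitrogen from the gain of the methyl groups. From the compounds shown here alone, it is also open how a ring carrying an amine or a carboxylic acid would behave here.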